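Acetoxyethyl in Place of Propanoyl on the Naphthalene Side Chain

The compounds below may be only part of what the source reports. "The series", "measured", "known", "first", "only" and "open" are said of these compounds alone.

Of the compounds shown here, three sharing one core have been measured in a functional assay on the whole organism (strain Wistar) for inhibition, with Rattus norvegicus as the target, with a stated time of 5 days, at a dose of 50 mg/kg by the oral route; a lower number here means less inhibition, a higher number more inhibition at the dose given (going by the name of the read-out). Compound 1, `COc1ccc2cc(C(C)CC(C)=O)ccc2c1`, gives 24%. Compound 2, `CCC(=O)CCc1ccc2cc(OC)ccc2c1`, gives 7%, the lowest of the three, and compound 3, `COc1ccc2cc(CCC3(C)OCCO3)ccc2c1`, gives 22%. The step of a number 17 percentage points lower from compound 1 to compound 2 (beyond the scatter) is beyond the scatter, as is the step of a number 15 percentage points higher from compound 2 to compound 3 (beyond the scatter). Compound 2 thus stands at the bottom of the group, with compound 3 its nearest neighbour.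

Compound 4, `COc1ccc2cc(CCC(C)OC(C)=O)ccc2c1`, is not yet measured. It differs from compound 2 in one place: 1-acetoxyethyl in place of propanoyl on a saturated chain carbon, two bonds along the chain from an aromatic carbon. Both measured steps swap a group at the same side-chain position and both are modest in size; the one leading away from propanoyl, a number 15 percentage points higher from compound 2 to compound 3 (beyond the scatter), raised the inhibition. For the measured compounds named here, only one such step is known, so the expectation is tentative. Compound 4 is therefore expected to show a modest rise, a number 11 percentage points higher from compound 2 to compound 4 (beyond the scatter), in this assay. Compound 4 is estimated at 18%, within a range of 4% to 32%.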

Compound 4, a percentage reported as inhibition, in the whole organism at one dose (the size of the read-out at that dose, not a potency): 38%
The estimate for compound 4 lay 20 percentage points below the measured number; measured number outside the range, above it.
By their numbers in this assay, from the lowest: compound 2; then compounds 3 and 1 (each within the scatter of the next); then compound 4.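

In this assay, for the compounds shown here, 1-acetoxyethyl in place of propanoyl on a saturated chain carbon, two bonds along the chain from an aromatic carbon, gives a number 31 percentage points higher from compound 2 to compound 4 (beyond the scatter), a large step where the earlier steps were modest. The two groups that replace propanoyl at this place also differ from each other, with a number 16 percentage points higher from compound 3 to compound 4 (beyond the scatter), so the number depends on which group enters and not only on propanoyl leaving. Nothing in the data explains why this group raises the inhibition.

The compounds shown leave open how a free alcohol, a 1-hydroxyethyl group, or a carboxylic acid would read at this place, and so whether the whole acetoxy unit is needed. As far as these compounds go, each number is also a read-out at a single dose, so the potency of compound 4 remains open.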